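From Trifluoromethyl to Fluoro on an Aromatic Carbon

The compounds below may be only part of what the source reports. "The series", "measured", "known", "first", "only" and "open" are said of these compounds alone.

- Compound 1 `CNC(=O)[C@@H](CO)NCc1ccc(OCc2ccccc2)cc1`: 22.8 mg/kg
- Compound 2 `CNC(=O)[C@@H](CO)NCc1ccc(OCc2cccc(C(F)(F)F)c2)cc1`: 13.1 mg/kg
- Compound 3 `CNC(=O)[C@@H](CO)NCc1ccc(OCc2cccc(F)c2)cc1`: not yet measured

Going by the values given here, in a functional assay on the whole organism with Mus musculus as the target, in the maximal electroshock model (on this read-out higher numbers stand for an effect only at larger amounts of compound and lower numbers for an effect already at smaller amounts), compound 2 gives 13.1 mg/kg, the lower of the two numbers so far, yet the one measured step, a 1.7-fold lower number from compound 1 to compound 2 (0.24 log units; within the scatter), does not separate it from compound 1. Among the compounds with values here, that step, trifluoromethyl in place of hydrogen on an aromatic carbon, is the only guide available. Compound 3 changes the same group: fluoro in place of trifluoromethyl on an aromatic carbon. Within the data shown here, with fluoro in place of trifluoromethyl on an aromatic carbon, no measured step shows this exact exchange. Since a 1.7-fold lower number from compound 1 to compound 2 (0.24 log units; within the scatter) stayed small, no step beyond the scatter is expected in this assay, and the expected move is a 1.2-fold higher number from compound 2 to compound 3 (0.09 log units; within the scatter). For compound 3 the estimate is 16 mg/kg, with an expected range from 9 mg/kg to 29 mg/kg.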

Compound 3, dose for half-maximal effect: 13 mg/kg
The estimate for compound 3 lay 1.2-fold (0.09 log units) above the measured number; measured number inside the range.
By their numbers in this assay, from the lowest: compounds 3, 2 and 1 (each within the scatter of the next).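

In this assay the exchange of trifluoromethyl, with its 4 heavy atoms, for fluoro, with its 1, is a step within the scatter (a 1.0-fold lower number from compound 2 to compound 3 (0.00 log units; within the scatter)), and fluoro in place of hydrogen is one as well (a 1.8-fold lower number from compound 1 to compound 3 (0.24 log units; within the scatter)). Going by these compounds alone, at this place, on an aromatic carbon meta to a large group, hydrogen, fluoro and trifluoromethyl therefore cannot be told apart on this read-out, which the single earlier step with trifluoromethyl could not show for a second group. Nothing available here explains why these three groups give numbers within the scatter of one another.

As far as these compounds go, it remains open whether an amine, a carboxylic acid or a longer chain at this same place would also stay within the scatter. From the compounds shown here alone, it is equally open whether fluoro would behave this way elsewhere on the core of compound 1.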